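The compounds below may be only part of what the source reports. "The series", "measured", "known", "first", "only" and "open" are said of these compounds alone.

Measured compounds in an assay on liver for inhibition of sterol O-acyltransferase 1 (Rattus norvegicus), using microsomes; on this read-out higher numbers stand for weaker inhibition and lower numbers for stronger inhibition:
compound 1, `CC(C)c1cccc(C(C)C)c1OC(=O)NS(=O)(=O)N1CCc2ccccc21`: 43000 nM
compound 2, `CC(C)c1cc([N+](=O)[O-])cc(C(C)C)c1OC(=O)NS(=O)(=O)Oc1c(C(C)C)cccc1C(C)C`: > 50000 nM

In this assay compound 1 gives 43000 nM. For compound 2 the result is a limit of the assay and not a number, > 50000 nM; this is the limit of > 50000 nM in this assay, at which 1 of the 2 values shown sits. On the numbers shown, compound 2 therefore stands only as a limit, without a measured value of its own.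

Compound 3, `CC(C)c1cc(F)cc(C(C)C)c1OC(=O)NS(=O)(=O)Oc1c(C(C)C)cccc1C(C)C`, differs from compound 2 by fluoro in place of nitro on an aromatic carbon. Among the measured compounds shown here, no step between measured compounds gives a gauge for this change, and compound 1 shares too little with compound 2 for a direct comparison. The step from compound 2 to compound 3 is expected to be a number no higher from compound 2 to compound 3 (the limit leaves the size open), with no direction beyond the scatter to be claimed. Compound 3 is estimated at 50000 nM, in the range 15000 nM to 150000 nM, and a limit rather than a number is a likely outcome.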

Compound 3, half-maximal inhibitory concentration: > 50000 nM
Compound 3 ended at the assay's limit (the forecaster's own chance of this, stated with the estimate: 55%); the middle value lies on the limit itself.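

In this assay compound 2 and compound 3 both stand as limits and not as numbers, so no step can be read for fluoro in place of nitro: the limit of > 50000 nM in this assay, at which 2 of the 3 values shown sit.
The compounds shown leave open the actual values of compound 2 and compound 3, and so whether this exchange alters inhibition at all.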